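The compounds below may be only part of what the source reports. "The series", "measured", "known", "first", "only" and "open" are said of these compounds alone.

Of the compounds shown here, three have been measured in an ADME assay on EA.hy 926 cells (Homo sapiens) for inhibition, read by sulforhodamine B assay, with a stated time of 72 h (a higher number here means a weaker inhibitor, a lower number a stronger inhibitor), and none gives a readable number. Compound 1 (`COc1cc(/C=C/C(=O)/C=C(/C=C/c2ccc(OC(C)=O)c(OC)c2)NC2CCCCC2)ccc1OC(C)=O`) gives > 25000 nM, which is a limit of the assay and not a number. Compound 3 (`CCC(C)NC(=C\C(=O)/C=C/c1ccc(OC(C)=O)c(OC)c1)/C=C/c1ccc(OC(C)=O)c(OC)c1`) gives > 25000 nM, again a limit. Going by these compounds, compound 2 (`CC(C)CNC(=C\C(=O)/C=C/c1ccc(O)cc1)/C=C/c1ccc(O)cc1`), the starting point here, gives > 25000 nM, also a limit, so its true position on the scale is unknown.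

Compound 4 (`O=C(/C=C(/C=C/c1ccc(O)cc1)NC1CCCCC1)/C=C/c1ccc(O)cc1`) keeps the core of compound 2 and changes one group: cyclohexyl in place of isobutyl on an amine nitrogen. In words, cyclohexyl takes the place of isobutyl on an amine nitrogen.

The closest measured comparison also involves cyclohexyl on that nitrogen: a step that the two limits leave unreadable from compound 1 to compound 3. It compares sec-butyl with cyclohexyl rather than isobutyl, and the two compounds carry a different core from compound 2, so it offers no size to carry over. The wider evidence is the limit of > 25000 nM in this assay, at which 3 of the 3 values shown sit.

No clear shift in either direction is expected because of the limit of > 25000 nM in this assay, at which 3 of the 3 values shown sit. The expected change is a step that the limit leaves unreadable from compound 2 to compound 4, and this estimate is only loosely held. Compound 4 is expected to sit near 30000 nM, with an estimated range of 12000 nM to 60000 nM, and the assay may well report only a limit again.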

Compound 4, half-maximal inhibitory concentration: 4200 nM
Compound 4: the middle estimate sits 7.1-fold (0.85 log units) above what was measured; the whole stated range lies above it.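

In this assay, replacing isobutyl with cyclohexyl on the amine nitrogen gives an at least 5.9-fold lower number from compound 2 to compound 4 (0.77 log units; beyond the scatter), which shows that the group at this position can change the result by more than the usual scatter on the core of compound 2. Compound 2 gives only a limit, so the true step may be larger, and no other pair offers a readable size to set beside it: the limit of > 25000 nM in this assay, at which 3 of the 4 values shown sit.

Cyclohexyl on this nitrogen is therefore not enough in every setting, since compound 1 also carries it, on a different core, and gives > 25000 nM, which is a limit of the assay.

The compounds shown leave open whether the gain depends on the ring itself or simply on having more carbon in the group, a question that a straight hexyl chain or a cyclopentyl group on the same nitrogen could help to separate. They also leave open whether a ring containing another kind of atom, such as a piperidine or a tetrahydropyran, would be accepted here on the core of compound 2.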